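This account rests on a few compounds, and the source may have more. Where it says the series, first, only, none or still open, it means among the compounds named here.

- Compound 1 `OCCCCC#Cc1ccccc1C#Cc1ccccn1` gives 9800 nM
- Compound 2 `OCCCCC#Cc1ccccc1C#Cc1cccs1` gives 13000 nM
- Compound 3 `OCCCCC#Cc1ccccc1C#Cc1cccc(O)c1` gives 17400 nM

In a functional assay on DU-145 cells (Homo sapiens) for cytotoxicity (a lower number here means a stronger inhibitor of growth, a higher number a weaker inhibitor of growth), compound 3 lies within the scatter of the other two compounds, with steps of a 1.3-fold higher number from compound 2 to compound 3 (0.13 log units; within the scatter) and a 1.8-fold higher number from compound 1 to compound 3 (0.25 log units; within the scatter) separating them. Compound 4 `OCCCCC#Cc1ccccc1C#Cc1ccc(O)cc1` has the same atoms as compound 3, joined differently, and the difference is 4-hydroxyphenyl in place of 3-hydroxyphenyl on a triple-bonded carbon on the same triple-bonded carbon. Within the data shown here, no measured pair makes this exact swap. The closest evidence comes from replacing the whole group at that place, and a 1.3-fold higher number from compound 1 to compound 2 (0.12 log units; within the scatter) also stayed within the scatter. No change beyond the scatter is therefore expected, and the estimated step is a 1.2-fold lower number from compound 3 to compound 4 (0.09 log units; within the scatter) at most a small one. For compound 4 the expected value is 14000 nM, with an estimated range of 7000 nM to 26000 nM.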

Compound 4, concentration for 50% growth inhibition: 16800 nM
The estimate for compound 4 lay 1.2-fold (0.08 log units) below the measured number; low and high end bracket the measured number.
By their numbers in this assay, from the lowest: compounds 1, 2, 4 and 3 (each within the scatter of the next).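

In this assay, 4-hydroxyphenyl in place of 3-hydroxyphenyl on the triple-bonded carbon gives a 1.0-fold lower number from compound 3 to compound 4 (0.02 log units; within the scatter) and so shows that these two arrangements of the same atoms cannot be told apart here. The thiophen-2-yl and pyridin-2-yl compounds also remain within the scatter of the new compound, with a 1.3-fold higher number from compound 2 to compound 4 (0.11 log units; within the scatter) and a 1.7-fold higher number from compound 1 to compound 4 (0.23 log units; within the scatter) as the steps to it. No measurement at hand offers an explanation for this result. On these data alone, whether an amine or a carboxylic acid on the ring at this place would give a step beyond the scatter remains open.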